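3,4-Dichlorophenyl to 2-chlorophenyl at the assay limit

This account rests on a few compounds, and the source may have more. Where it says the series, first, only, none or still open, it means among the compounds named here.

Compound 1 `COc1ccc(C(=O)/C=C/c2ccc([N+](=O)[O-])cc2)c2c1C=CC(C)(C)O2`: 2610 nM
Compound 2 `COc1ccc(C(=O)/C=C/c2ccsc2)c2c1C=CC(C)(C)O2`: > 10000 nM (a limit)
Compound 3 `COc1ccc(C(=O)/C=C/c2ccc(Cl)c(Cl)c2)c2c1C=CC(C)(C)O2`: > 10000 nM (a limit)
Compound 4 `COc1ccc(C(=O)/C=C/c2ccccc2Cl)c2c1C=CC(C)(C)O2`: not yet measured

In a functional assay on HepG2 cells (Homo sapiens) for antiproliferative activity, read by MTT assay, with a stated time of 24 h (on this read-out lower numbers stand for stronger inhibition and higher numbers for weaker inhibition), compound 3 gives only a limit, > 10000 nM, and no number. That value is the limit of > 10000 nM in this assay, at which 2 of the 3 values shown sit. The change to compound 4 is 2-chlorophenyl in place of 3,4-dichlorophenyl on a double-bonded chain carbon bound to a double-bonded chain carbon. Within the data shown here, two measured steps bear on it: an at least 3.8-fold higher number from compound 1 to compound 3 (0.58 log units; beyond the scatter) and an at least 3.8-fold higher number from compound 1 to compound 2 (0.58 log units; beyond the scatter). Both lie beyond the scatter, and a step that the two limits leave unreadable from compound 2 to compound 3. With an at least 3.8-fold higher number from compound 1 to compound 3 (0.58 log units; beyond the scatter) as the closest guide, compound 4, which also lacks the 4-nitrophenyl group, is expected to stay near that limit, with no readable change in this assay. The expected step is a number no higher from compound 3 to compound 4 (the limit leaves the size open). For compound 4 the estimated value is 10000 nM, with an expected range of 3000 nM to 30000 nM.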

Compound 4, half-maximal inhibitory concentration: > 10000 nM
Compound 4 gave a limit, no number; the forecaster's own chance of this, stated with the estimate: 65%; the middle value lies on the limit itself.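

In this assay, compound 4 gives a limit and no number, so 2-chlorophenyl in place of 3,4-dichlorophenyl brings no readable activity at this position. Its step from the 4-nitrophenyl compound is an at least 3.8-fold higher number from compound 1 to compound 4 (0.58 log units; beyond the scatter), while the steps among compound 2, compound 3 and compound 4 cannot be read. A single chlorine on the phenyl ring thus leaves compound 4 where the dichloro and thiophen-3-yl compounds stand: the limit of > 10000 nM in this assay, at which 3 of the 4 values shown sit.

From the compounds shown here alone, the order of these three compounds remains unknown. Going by these compounds, it also remains open whether an amine or a carboxylic acid in place of the nitro group would give a number.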